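Swapping a dichlorobenzyl for a methoxybenzyl on a shared core

A few compounds are considered here, and "the series" means these few. Any claim that something is new, unique, unknown or untested is made for them only; others in the source may bear on it.

Compound 3 `Nc1cc(N)c2nc(-c3ccccc3)c(NCc3ccc(Cl)c(Cl)c3)nc2c1` gives 12300 nM in a functional assay on MCF7 cells (Homo sapiens) for inhibition, read by sulforhodamine B assay, with a stated time of 48 h (on this read-out higher numbers stand for weaker inhibition of growth and lower numbers for stronger inhibition of growth), the lowest of the two numbers in hand. Compound 1 `Nc1cc(N)c2nc(-c3ccccc3)c(Oc3ccc(Cl)c(Cl)c3)nc2c1` sits within the scatter of it, giving 14100 nM in this assay. Compound 2 `CCOC(=O)[C@H](CCC(=O)O)NC(=O)c1ccc(CNc2nc3cc(N)cc(N)c3nc2-c2ccccc2)cc1` is reported in this assay only as a limit of < 100000 nM, not as a number. Compound 4 `COc1ccc(CNc2nc3cc(N)cc(N)c3nc2-c2ccccc2)cc1` differs from compound 3 by 4-methoxyphenyl in place of 3,4-dichlorophenyl on a saturated chain carbon bound to a nitrogen on an aromatic ring. Among the measured compounds shown here, there is no measured step among the compounds in hand. A shift toward weaker inhibition is expected, a 1.6-fold higher number from compound 3 to compound 4 (0.21 log units; within the scatter), close to the edge of the scatter. Compound 4 is therefore expected to give about 20000 nM in this assay, between 6000 nM and 70000 nM.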

Compound 4, concentration for 50% growth inhibition: 13200 nM
Estimate against measurement, compound 4: 1.5-fold (0.18 log units) above, and the stated range covers the measured number.
By their numbers in this assay, from the lowest: compounds 3, 4 and 1 (each within the scatter of the next).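

In this assay the change brings a 1.1-fold higher number from compound 3 to compound 4 (0.03 log units; within the scatter), so on a saturated chain carbon bound to a nitrogen on an aromatic ring, 3,4-dichlorophenyl and 4-methoxyphenyl cannot be told apart. Among the compounds shown here, this is the first step read at this position, and it shows that the two chlorine atoms can give way to a methoxy group, with its one hydrogen-bond acceptor, without a change beyond the scatter. Nothing shown gives a reason for this.

As far as these compounds go, whether an amine, a carboxylic acid or a longer chain at this place would keep the number within the same scatter stays open.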